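The source may report more compounds than this note shows. Statements on the series, on what has been measured and on what is new or still open speak of the compounds shown alone.

The measured compounds:

compound 1, `O=C(Nc1ccc(S(=O)(=O)N2CCC(Cl)CC2)cc1)c1ccc([N+](=O)[O-])o1` — > 20000 nM
compound 2, `CC1CCN(S(=O)(=O)c2ccc(NC(=O)c3ccc([N+](=O)[O-])o3)cc2)CC1` — 16300 nM

Compound 1 is the starting point. In a functional assay on MEF cells (Mus musculus) for antiproliferative activity, read by luminescence, with a stated time of 16 h (a higher number here means that more compound is needed for the effect, a lower number that less compound is needed), compound 1 gives > 20000 nM, which is a limit of the assay and not a number. Compound 2, carrying methyl in place of chloro on a saturated ring carbon, gives 16300 nM in this assay, a number only just inside the range the assay reports. For the measured compounds named here, the step of an at least 1.2-fold lower number from compound 1 to compound 2 (0.08 log units; that floor lies within the scatter) is therefore the sole measured comparison at this position, and it lies within the scatter.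

Compound 3, `CC(C)(C)C1CCN(S(=O)(=O)c2ccc(NC(=O)c3ccc([N+](=O)[O-])o3)cc2)CC1`, differs from compound 1 by tert-butyl in place of chloro on a saturated ring carbon. Going by the values given here, the only step that bears on this change is the one to compound 2, which was small, and no measured compound carries tert-butyl, so there is no direct guide for a group of this size. The expectation is thus for no step beyond the scatter in this assay; compound 3 is estimated at 20000 nM, with a range from 8000 nM to 50000 nM. This expected value means a step of a number no higher from compound 1 to compound 3 (the limit leaves the size open). Given (the limit of > 20000 nM in this assay, at which 1 of the 2 values shown sits), the chance that compound 3 again returns only a limit is judged high.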

Compound 3, half-maximal effective concentration: 2100 nM
Beside the measured number, compound 3's estimate is 9.5-fold (0.98 log units) above it; the measured number lies below the stated range.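

In this assay, the group on this saturated ring carbon does make a difference, which the change from chloro to methyl alone had not shown: tert-butyl in place of chloro gives an at least 9.5-fold lower number from compound 1 to compound 3 (0.97 log units; beyond the scatter) and so moves the result beyond the scatter. The comparison with methyl is the firmer reading, since tert-butyl in place of methyl gives a 7.8-fold lower number from compound 2 to compound 3 (0.89 log units; beyond the scatter) and both ends of that step are numbers. The step from chloro remains only a floor because compound 1 stands at a limit of the assay and not at a number: the limit of > 20000 nM in this assay, at which 1 of the 3 values shown sits.

The compounds shown carry only chloro, methyl and tert-butyl at this ring carbon, so they leave open whether an isopropyl group or a cyclohexyl group would read like methyl or like tert-butyl, and whether the change depends on the branched shape of tert-butyl or on its carbon count. They also leave open how an amine or a carboxylic acid at this carbon would read, and whether the same step would hold with any other change elsewhere on the shared core.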